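A few compounds are considered here, and "the series" means these few. Any claim that something is new, unique, unknown or untested is made for them only; others in the source may bear on it.

Working notes on the series. Compound 1 `COc1cc(/C=C/C(=O)c2cccc(-n3cc(-c4ccc(Cl)cc4)[nH]c3=O)c2)cc(OC)c1OC` is measured in a functional assay on Hs-578T cells (Homo sapiens) for inhibition (a higher number here means a weaker inhibitor of growth, a lower number a stronger inhibitor of growth), and gives 5960 nM there. Compound 2 `O=C(/C=C/c1cccc(O)c1)c1cccc(-n2cc(-c3ccc(Cl)cc3)[nH]c2=O)c1` gives 4000 nM in this assay. Within the data shown here, of these two numbers the one for compound 1 is the higher, but the gap between compound 1 and compound 2 lies within the usual scatter of this measurement, so nothing about order can be read from it. Among the measured compounds shown here, no pair of measured compounds differs in a single place, so no measured step is available to set the scale for what a single change does here.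

Compound 3 `COc1cc(/C=C/C(=O)c2cccc(-n3cc(-c4cc(OC)c(OC)c(OC)c4)[nH]c3=O)c2)cc(OC)c1OC` has not yet been measured in this assay. Relative to compound 1 it carries the change (3,4,5-trimethoxyphenyl in place of 4-chlorophenyl on an aromatic carbon). The two measured numbers give no guide for this change, so the step from compound 1 to compound 3 is expected to be modest, a 1.7-fold lower number from compound 1 to compound 3 (0.23 log units; within the scatter), and may well stay within the scatter. On that basis compound 3 is estimated at 3500 nM in this assay, with a range from 900 nM to 14000 nM.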

Compound 3, concentration for 50% growth inhibition: "not active" (no number reported)
The entry for compound 3 holds no number; no gap can be computed for the estimate.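

In this assay, among these compounds, compound 3 is recorded as "not active" without a number, so no step from compound 1 to compound 3 can be read. No data shown bear on the cause of this result. The compounds shown leave open how large the effect of 3,4,5-trimethoxyphenyl in place of 4-chlorophenyl is.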